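Solubility notes: compound 3 against the bromo and methoxy pair

The source may report more compounds than this note shows. Statements on the series, on what has been measured and on what is new or still open speak of the compounds shown alone.

Two compounds of this series carry numbers. Compound 1 `CCc1ccc(-c2nc3c(c(C)nn3-c3ccccc3)c(-c3ccccc3Br)c2C#N)cc1` gives 1500 nM in a physicochemical assay for solubility, read by spectrophotometry, in phosphate buffer, with a stated time of 18 h, at pH 7.4 (on this read-out higher numbers stand for higher solubility and lower numbers for lower solubility), the lower of the two values known. Within the data shown here, compound 2 `CCc1ccc(-c2nc3c(c(C)nn3-c3ccccc3)c(-c3ccccc3OC)c2C#N)cc1` gives 7800 nM in this assay, and the single step, a 5.2-fold higher number from compound 1 to compound 2 (0.72 log units; beyond the scatter), is the only one that bears on the change under review.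

Compound 3 `CCc1ccc(-c2nc3c(c(C)nn3-c3ccccc3)c(-c3cccc(O)c3)c2C#N)cc1` differs from compound 1 at the same aromatic carbon: 3-hydroxyphenyl in place of 2-bromophenyl on an aromatic carbon. The step from compound 1 to compound 2 swaps one group on that ring; the step to compound 3 swaps the whole ring substituent and brings in a hydrogen-bond donor and acceptor where none stood. The change is expected to move the number in the same direction as the measured step, because a 5.2-fold higher number from compound 1 to compound 2 (0.72 log units; beyond the scatter) already points upward for a replacement of the bromo.

Compound 3 is therefore estimated at 8000 nM, range 2500 nM to 25000 nM, a step of a 5.3-fold higher number from compound 1 to compound 3 (0.73 log units; beyond the scatter) expected in this assay.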

Compound 3, solubility: 18000 nM
For compound 3 the middle estimate is 2.3-fold (0.35 log units) below the measured one, within the range that was stated.
By their numbers in this assay, from the lowest: compound 1; then compound 2; then compound 3.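

At this carbon, opposite the ring nitrogen, exchange of the whole aryl group goes further than the swap of bromo for methoxy: in this assay the change gives a 12-fold higher number from compound 1 to compound 3 (1.08 log units; beyond the scatter). The rise continues past the methoxy compound, with a 2.3-fold higher number from compound 2 to compound 3 (0.36 log units; beyond the scatter), so 3-hydroxyphenyl now marks the top of the three and 2-methoxyphenyl no longer sets the upper end at this position. Nothing on hand says what lies behind these rises.

Compound 2 and compound 3 differ both in hydroxy against methoxy and in where that group sits on the ring, so the two contributions cannot be separated from these numbers. From the compounds shown here alone, whether an amine or a carboxylic acid on the same ring would carry the number further stays open.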